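A few compounds are considered here, and "the series" means these few. Any claim that something is new, unique, unknown or untested is made for them only; others in the source may bear on it.

Compound 2 `Cc1cc(C#N)cc(C)c1Oc1nc(Nc2ccc(C#N)cc2)ncc1-c1ccco1` is the starting point of this step. In an ADME assay on MT4 cells (Homo sapiens) for cytotoxicity, read by MTT assay, with a stated time of 5 days (on this read-out lower numbers stand for higher toxicity in this test and higher numbers for lower toxicity in this test), compound 2 gives only > 306000 nM, which is a limit of the assay rather than a number. Compound 2 sits at the limit of > 306000 nM in this assay, at which 1 of the 2 values shown sits. Compound 3 `Cc1cc(C#N)cc(C)c1Oc1nc(Nc2ccc(C#N)cc2)ncc1-c1ccc(C(F)(F)F)cc1` differs from compound 2 in one place: 4-(trifluoromethyl)phenyl in place of furan-2-yl on an aromatic carbon. Among the measured compounds shown here, only one measured step offers a guide. Compound 1 `Cc1cc(C)cc(-c2cnc(Nc3ccc(C#N)cc3)nc2Oc2c(C)cc(C#N)cc2C)c1` carries 3,5-dimethylphenyl on an aromatic carbon and gives 39000 nM in this assay. Exchanging that group for furan-2-yl produced an at least 7.8-fold higher number from compound 1 to compound 2 (0.89 log units; beyond the scatter), a move toward lower toxicity. Compound 3 goes the other way, returning a six-membered aromatic ring of carbon only in place of the five-membered aromatic ring, so toxicity is expected to move back toward the level seen for compound 1, although 4-(trifluoromethyl)phenyl is not 3,5-dimethylphenyl and the size of the move is uncertain. The expected step is an at least 4.3-fold lower number from compound 2 to compound 3 (0.64 log units; beyond the scatter) in this assay, with a real chance that only a limit is reached again. In this assay the estimated value for compound 3 is 70000 nM, within a range from 15000 nM to 306000 nM.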

Compound 3, half-maximal cytotoxic concentration: 35000 nM
The estimate for compound 3 lay 2.0-fold (0.30 log units) above the measured number; the range from low to high includes it.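

With a second substituted phenyl group now at this position, the picture in this assay becomes clearer: the two groups that are six-membered aromatic rings of carbon only, 3,5-dimethylphenyl and 4-(trifluoromethyl)phenyl, cannot be told apart, with a 1.1-fold lower number from compound 1 to compound 3 (0.05 log units; within the scatter). Compound 1 alone could not show whether the earlier gain belonged to furan-2-yl itself or merely to the loss of the two methyl groups, but the return to a substituted phenyl ring with different substituents gives an at least 8.7-fold lower number from compound 2 to compound 3 (0.94 log units; beyond the scatter), so among these three compounds the lower toxicity in this test goes with furan-2-yl and not with one particular phenyl substitution. The true size of that step remains unknown, as compound 2 is represented by a limit of the assay and not by a number: the limit of > 306000 nM in this assay, at which 1 of the 3 values shown sits.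

Among the compounds shown here, the three compounds do not separate the size of the ring from the oxygen atom in it, and they rest on only one five-membered ring. A thiophen-2-yl group, with sulfur in place of oxygen, and a pyridine ring, with nitrogen in a six-membered ring, would each bear on that question.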